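The source may report more compounds than this note shows. Statements on the series, on what has been measured and on what is new or still open speak of the compounds shown alone.

Measured so far in a functional assay (aorta) with Rattus norvegicus as the target; on this read-out lower numbers stand for stronger inhibition and higher numbers for weaker inhibition: compound 1 `CCO/C(O)=C1\C(COCCNC(=O)c2cccnc2)=NC(C)=C(C(=O)OC)C1c1ccccc1Cl` gives 15.9 nM; compound 2 `CCO/C(O)=C1\C(COCCNC(=O)NCCN2CCNC2=O)=NC(C)=C(C(=O)OC)C1c1ccccc1Cl` gives 15.9 nM.

For the measured compounds named here, compound 2 stands level with compound 1, the only step measured being no change at the digits printed from compound 1 to compound 2 (within the scatter). Compound 3 `CCO/C(O)=C1\C(COCCNC(C)C(N)=O)=NC(C)=C(C(=O)OC)C1c1ccccc1Cl` differs from compound 2 as follows: 1-carbamoylethyl in place of (2-(2-oxoimidazolidin-1-yl)ethyl)carbamoyl on an amine nitrogen. Going by the values given here, the single measured step bears on it only loosely, since that step exchanged groups on a carbonyl carbon and left this assay unchanged within the scatter. On that slender basis the expected step is a 1.0-fold higher number from compound 2 to compound 3 (0.00 log units; within the scatter), none beyond the scatter. Compound 3 is therefore estimated at 16 nM, within 6 nM to 45 nM.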

Compound 3, half-maximal inhibitory concentration: 10 nM
Compound 3: middle estimate off by 1.6-fold (0.20 log units), on the high side; low and high end bracket the measured number.
By their numbers in this assay, from the lowest: compounds 3, 1 and 2 (each within the scatter of the next).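

In this assay, the amine nitrogen accepts a smaller group with no ring: 1-carbamoylethyl in place of (2-(2-oxoimidazolidin-1-yl)ethyl)carbamoyl gives a 1.6-fold lower number from compound 2 to compound 3 (0.20 log units; within the scatter) and in place of (pyridin-3-yl)carbonyl gives a 1.6-fold lower number from compound 1 to compound 3 (0.20 log units; within the scatter) in the same read-out. Compounds 1 and 2 both carry a carbonyl on this nitrogen, whereas compound 3 has none there, and its number stays within the scatter of theirs. Nothing available explains this.

Going by these compounds, it remains open whether a carboxylic acid or an amine in place of the carbamoyl would keep the number within this range. The same question stands for a longer chain on this nitrogen.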